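This account rests on a few compounds, and the source may have more. Where it says the series, first, only, none or still open, it means among the compounds named here.

Compound 2 (`O=C(/C=C/c1cccs1)c1cccc(NC(=O)c2cc(-c3ccncc3)n[nH]2)c1`) reads 70000 nM in a functional assay, read by spectrophotometry, tested at 100 uM (on this read-out higher numbers stand for weaker inhibition and lower numbers for stronger inhibition), and has two close relatives on that scale, with compound 1 (`O=C(/C=C/c1ccccc1)c1cccc(NC(=O)c2cc(-c3ccncc3)n[nH]2)c1`) at 71500 nM and compound 3 (`COc1cc(/C=C/C(=O)c2cccc(NC(=O)c3cc(-c4ccncc4)n[nH]3)c2)cc(OC)c1OC`) at 52900 nM; all three lie within the scatter of one another. The step followed here leads to compound 4 (`COc1ccccc1/C=C/C(=O)c1cccc(NC(=O)c2cc(-c3ccncc3)n[nH]2)c1`), which has 2-methoxyphenyl in place of thiophen-2-yl on a double-bonded chain carbon bound to a double-bonded chain carbon. Among the compounds with values here, three measured steps bear on it, all at this same place. Thiophen-2-yl in place of phenyl gave a 1.0-fold lower number from compound 1 to compound 2 (0.01 log units; within the scatter) and 3,4,5-trimethoxyphenyl in place of phenyl gave a 1.4-fold lower number from compound 1 to compound 3 (0.13 log units; within the scatter) as its result. The closest parallel, 3,4,5-trimethoxyphenyl in place of thiophen-2-yl, gave a 1.3-fold lower number from compound 2 to compound 3 (0.12 log units; within the scatter) as well. Within the data shown here, no measured compound yet carries 2-methoxyphenyl itself, so the evidence is indirect. Going by these three small steps, no change beyond the scatter is expected in this assay, and neither direction is favoured. The expected step is a 1.1-fold lower number from compound 2 to compound 4 (0.05 log units; within the scatter) and no more. For compound 4 the estimated value is 62000 nM (expected range 38000 nM to 100000 nM).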

Compound 4, half-maximal inhibitory concentration: 56700 nM
Estimate against measurement, compound 4: 1.1-fold (0.04 log units) above; measured number inside the range.
By their numbers in this assay, from the lowest: compounds 3, 4, 2 and 1 (each within the scatter of the next).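

Compound 4 puts a single methoxy on the phenyl of compound 1, and in this assay methoxy in place of hydrogen on an aromatic carbon gave a 1.3-fold lower number from compound 1 to compound 4 (0.10 log units; within the scatter), so this one added group shifts the number by no more than the scatter. The position also tolerates a change in ring type and in methoxy count without a readable shift: 2-methoxyphenyl in place of thiophen-2-yl gave a 1.2-fold lower number from compound 2 to compound 4 (0.09 log units; within the scatter), and 2-methoxyphenyl in place of 3,4,5-trimethoxyphenyl gave a 1.1-fold higher number from compound 3 to compound 4 (0.03 log units; within the scatter). With this fourth compound, all the groups compared at this place, one five-membered aromatic ring and three six-membered ones carrying none, one or three methoxy groups, stay within the scatter of one another, and no measurement is at hand that would account for this flat result.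

Going by these compounds, all four compounds carry an aromatic ring at this place, so it remains open whether an amine, a carboxylic acid or a longer chain there would move the number beyond the scatter. On these data alone, it is also open whether a methoxy on a different aromatic carbon, or a change elsewhere on the shared core, would do so.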